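The compounds below may be only part of what the source reports. "The series", "measured", "known", "first", "only" and "open" are said of these compounds alone.

Measured compounds:
compound 1, `CC1=CC[C@H]2[C@H](CC[C@]2(C)O)C(C)(C)[C@@H]1CC[C@H]1[C@]2(C)CC[C@H](OC(=O)c3ccc(C)cc3)C(C)(C)O[C@H]2CC[C@@]1(C)O`, 33400 nM
compound 2, `CC1=CC[C@H]2[C@@H]1CC=C(C)[C@@H](CC[C@H]1[C@]3(C)CC[C@H](OC(=O)c4ccc(Cl)cc4)C(C)(C)O[C@H]3CC[C@@]1(C)O)C2(C)C`, 12700 nM

Both were tested in a functional assay on MDA-MB-231 cells (Homo sapiens) for antiproliferative activity, read by MTT assay, with a stated time of 72 h; a lower number here means a stronger inhibitor, a higher number a weaker inhibitor. Of the two measured compounds, compound 1 gives the highest number; its nearest neighbour, compound 2, lies below it by a margin beyond the usual scatter. The two differ in more than one place, so their gap is taken only as it stands and is not traced to any single change.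

Compound 3, `CC1=CC[C@H]2[C@H](CC[C@]2(C)O)C(C)(C)[C@@H]1CC[C@H]1[C@]2(C)CC[C@H](OC(=O)c3ccc(C(F)(F)F)cc3F)C(C)(C)O[C@H]2CC[C@@]1(C)O`, has not yet been measured. It derives from compound 1 by one change: 2-fluoro-4-(trifluoromethyl)phenyl in place of 4-methylphenyl on a carbonyl carbon. Within the data shown here, no measured pair shows this change on its own, so its effect in this assay cannot be read directly from the data. A moderate step is expected, on balance toward a lower number, though a step that stays within the scatter cannot be ruled out.

For compound 3 the expected value in this assay is 20000 nM, with a range from 7000 nM to 60000 nM. This estimate corresponds to an expected step of a 1.7-fold lower number from compound 1 to compound 3 (0.22 log units; within the scatter).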

Compound 3, half-maximal inhibitory concentration: 36300 nM
Estimate against measurement, compound 3: 1.8-fold (0.26 log units) below, and the stated range covers the measured number.
By their numbers in this assay, from the lowest: compound 2; then compounds 1 and 3 (each within the scatter of the next).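

In this assay, the swap of 4-methylphenyl for 2-fluoro-4-(trifluoromethyl)phenyl on a carbonyl carbon can now be read directly, as a 1.1-fold higher number from compound 1 to compound 3 (0.04 log units; within the scatter). The aromatic ring stays a six-membered ring of carbon only, while the entering group carries 4 fluorine and has 11 heavy atoms against 7, yet compound 1 and compound 3 cannot be told apart in this assay, so this position tolerates this particular replacement without a measurable difference. Nothing measured on these compounds bears on why the two numbers lie so close.

The compounds shown leave open whether any group on this carbonyl carbon can move the number beyond the scatter, for instance a phenyl ring bearing an amine or a carboxylic acid, or a longer alkyl chain in place of the aromatic ring. Among these compounds, they also leave open whether the same replacement would read the same way on the core of compound 2, since that core appears here with only one group on its carbonyl carbon.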